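Dropping a Chloro Group from a Weak Antiproliferative Compound

This account rests on a few compounds, and the source may have more. Where it says the series, first, only, none or still open, it means among the compounds named here.

So far, a set of related compounds sharing a related shape has been measured. Compound 1 `O=c1cc(CSC(=S)N2CCCCC2)oc2ccccc12` carries no chloro group. Compound 2 `O=c1c(Cl)c(CSC(=S)N2CCCCC2)oc2ccccc12` adds a chloro on an aromatic carbon, while compound 3 `CC(C)N(C(=S)SCc1cc(=O)c2ccc(Cl)cc2o1)C(C)C` carries its chloro on a different ring and has a different amine part. In a functional assay on HEp-2 cells (Homo sapiens) for antiproliferative activity, read by MTT assay, with a stated time of 72 h (a higher number here means a weaker inhibitor, a lower number a stronger inhibitor), compound 1 gives 12000 nM, compound 2 gives 940 nM, and compound 3 gives 22700 nM. Compound 3 shows the highest of the three numbers, but its gap to compound 1 lies within the scatter, so those two cannot be ordered; its gap to compound 2 lies beyond the scatter. How the cores of compound 2 and compound 3 differ is not broken down here.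

Among the compounds with values here, the one counted step is hydrogen in place of chloro on an aromatic carbon, and it made a 13-fold higher number from compound 2 to compound 1 (1.11 log units; beyond the scatter).

Compound 4 `CC(C)N(C(=S)SCc1cc(=O)c2ccccc2o1)C(C)C` is not yet measured. It arises from compound 3 by hydrogen in place of chloro on an aromatic carbon. Within the data shown here, this is the same kind of change as the one from compound 2 to compound 1, but not the same: in compound 2 the chloro sits on a six-membered aromatic ring with 1 oxygen, ortho to a group of 1 heavy atom, ortho to a large group and two atoms from the ring oxygen, whereas in compound 3 it sits on a six-membered aromatic ring of carbon only.

Among the measured compounds shown here, only that earlier step offers guidance, and it was measured at a different place, so the step expected from compound 3 to compound 4 in this assay is a 1.8-fold higher number from compound 3 to compound 4 (0.25 log units; within the scatter), gentler than the earlier one. Compound 4 is therefore estimated at 40000 nM, with a likely range from 12000 nM to 150000 nM, and there is a fair chance that the assay reports only a limit.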

Compound 4, half-maximal inhibitory concentration: 13600 nM
Compound 4: middle estimate off by 2.9-fold (0.47 log units), on the high side, within the range that was stated.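

In this assay, hydrogen in place of chloro on the carbon-only ring gave a 1.7-fold lower number from compound 3 to compound 4 (0.22 log units; within the scatter), and diisopropylamino in place of piperidin-1-yl gave a 1.1-fold higher number from compound 1 to compound 4 (0.05 log units; within the scatter). The same kind of replacement therefore does not bring one fixed effect to every core in this series, since removing the chloro mattered clearly in one case and gave no readable change in the other: the same change on two cores in this assay, a 13-fold higher number (1.11 log units; beyond the scatter) from compound 2 to compound 1 and a 1.7-fold lower number (0.22 log units; within the scatter) from compound 3 to compound 4, 21-fold (1.33 log units) apart, beyond the scatter of two such steps. This does not show what separates the two cases, as the chloro sits on a different ring in compound 2 and compound 3, and the amine part differs as well, so these pairs cannot tell the contribution of the chloro's place from that of the amine part.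

Still open, from the compounds shown here alone, is whether a chloro placed as in compound 2 would bring a similar gain when the amine part is diisopropylamino, a test that would separate those two differences. Also open, going by these compounds, is how a fluoro or a methyl would compare with the chloro at either place, and whether a morpholine as the amine part would match piperidin-1-yl and diisopropylamino.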